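The compounds below may be only part of what the source reports. "The series", "measured", "known", "first", "only" and "open" are said of these compounds alone.

Among the measured compounds shown here, compound 3 `CC(C)c1c(C(=O)NCc2ccccc2Cl)nn(-c2ccc(F)cc2)c1OC[C@@H](O)C[C@@H](O)CC(=O)O` gives 9.5 nM in an assay on microsomes from liver for inhibition of 3-hydroxy-3-methylglutaryl-coenzyme A reductase (Rattus norvegicus) (on this read-out lower numbers stand for stronger inhibition and higher numbers for weaker inhibition), the lowest of the three numbers so far. Compound 1 `CC(C)c1c(C(=O)NCC2CCCCC2)nn(-c2ccc(F)cc2)c1OC[C@@H](O)C[C@@H](O)CC(=O)O` gives 17 nM in this assay, and compound 2 `COc1ccccc1CNC(=O)c1nn(-c2ccc(F)cc2)c(OC[C@@H](O)C[C@@H](O)CC(=O)O)c1C(C)C` gives 22 nM in this assay. The step of a 1.8-fold lower number from compound 1 to compound 3 (0.25 log units; within the scatter) stays within the scatter, while a 2.3-fold lower number from compound 2 to compound 3 (0.36 log units; beyond the scatter) goes beyond it; a 1.3-fold higher number from compound 1 to compound 2 (0.11 log units; within the scatter) is also within the scatter.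

Compound 4 `CC(C)c1c(C(=O)N(C)Cc2cccc(Cl)c2)nn(-c2ccc(F)cc2)c1OC[C@@H](O)C[C@@H](O)CC(=O)O` differs from compound 3 by (3-chlorobenzyl)(methyl)amino in place of (2-chlorobenzyl)amino on a carbonyl carbon. The measured steps vary only the group on the saturated chain carbon bound to the amide-type nitrogen, and all were modest, as a 1.3-fold higher number from compound 1 to compound 2 (0.11 log units; within the scatter), a 1.8-fold lower number from compound 1 to compound 3 (0.25 log units; within the scatter) and a 2.3-fold lower number from compound 2 to compound 3 (0.36 log units; beyond the scatter) show. On these data alone, none of them tests a methyl on the amide-type nitrogen or a chloro moved to a new position, so the change to compound 4 is untested in two ways, and a step beyond the scatter in this assay in either direction is possible. Compound 4 is expected to give 30 nM in this assay, within 10 nM to 100 nM, which would mean an estimated step of a 3.2-fold higher number from compound 3 to compound 4 (0.50 log units; beyond the scatter).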

Compound 4, half-maximal inhibitory concentration: 8.3 nM
The estimate for compound 4 lay 3.6-fold (0.56 log units) above the measured number, outside the stated range (below it).
By their numbers in this assay, from the lowest: compounds 4, 3, 1 and 2 (each within the scatter of the next, the first and the last beyond it).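

In this assay the step of a 1.1-fold lower number from compound 3 to compound 4 (0.06 log units; within the scatter) stays within the scatter, so at this carbonyl carbon the amide hydrogen can be lost, with a methyl on the nitrogen and the chloro moved, without a step beyond the scatter. The steps of a 2.7-fold lower number from compound 2 to compound 4 (0.42 log units; beyond the scatter) and a 2.0-fold lower number from compound 1 to compound 4 (0.31 log units; beyond the scatter) are modest but beyond the scatter, so the tertiary amide of compound 4 keeps the number at the low end of this set, although compound 4 differs from each of these two compounds in more than the methyl alone. No measurement given here accounts for these results.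

The two changes in compound 4 remain unseparated, since (3-chlorobenzyl)amino and (2-chlorobenzyl)(methyl)amino are not among the compounds shown. Also open, on these data alone, is whether a larger group on this nitrogen, such as ethyl, or a ring-bound amine such as piperidine in its place, would give a similar number.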